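This account rests on a few compounds, and the source may have more. Where it says the series, first, only, none or still open, it means among the compounds named here.

In a functional assay on RAW264.7 cells (Mus musculus) for inhibition, read by Griess assay, with stated times of 1 h and 24 h (on this read-out lower numbers stand for stronger inhibition and higher numbers for weaker inhibition), compound 1 `CCOc1ccc(C(O)C2OC(=O)c3c(OC)cc(OC)cc32)cc1` gives > 10000 nM, which is a limit of the assay and not a number. Compound 2 `CCOCCOc1ccc(C(O)C2OC(=O)c3c(OC)cc(OC)cc32)cc1` gives > 10000 nM, again a limit. Among the measured compounds shown here, compound 3 `COc1cc(OC)c2c(c1)C(C(O)c1ccc(OCc3ccc(C#N)cc3)cc1)OC2=O` gives 7360 nM, the only true number so far. Compound 4 `COc1cc(OC)c2c(c1)C(C(O)c1ccc(OCc3ccc(OC(F)(F)F)cc3)cc1)OC2=O` differs from compound 3 in one place: trifluoromethoxy in place of cyano on an aromatic carbon. For the measured compounds named here, no measured step swaps that group. The nearest evidence is an at least 1.3-fold lower number from compound 1 to compound 3 (0.13 log units; that floor lies within the scatter) and an at least 1.3-fold lower number from compound 2 to compound 3 (0.13 log units; that floor lies within the scatter), two floors that lie within the scatter, while a step that the two limits leave unreadable from compound 1 to compound 2 cannot be read. No change beyond the scatter is therefore expected, and the expected step is a 1.1-fold lower number from compound 3 to compound 4 (0.05 log units; within the scatter). For compound 4 the estimated value is 6500 nM, within an expected range of 2500 nM to 14000 nM.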

Compound 4, half-maximal inhibitory concentration: 8140 nM
Compound 4: the middle estimate sits 1.3-fold (0.10 log units) below what was measured, and the stated range covers the measured number.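

In this assay, the swap on this aromatic carbon, para to a large group, gives the first step readable between two true numbers: a 1.1-fold higher number from compound 3 to compound 4 (0.04 log units; within the scatter). Cyano and trifluoromethoxy therefore cannot be told apart here, even though the entering group is the larger by heavy atoms. The other two steps, an at least 1.2-fold lower number from compound 2 to compound 4 (0.08 log units; that floor lies within the scatter) and an at least 1.2-fold lower number from compound 1 to compound 4 (0.08 log units; that floor lies within the scatter), are only floors, because the compounds they start from sit at a limit: the limit of > 10000 nM in this assay, at which 2 of the 4 values shown sit.

From the compounds shown here alone, whether an amine or a carboxylic acid on this aromatic carbon would move the number beyond the scatter remains open. So does the effect of a longer chain there.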